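Moving the Hydroxamic Acid Around the Ring

The compounds below may be only part of what the source reports. "The series", "measured", "known", "first", "only" and "open" are said of these compounds alone.

Compound 1 `O=C(NO)c1ccc(-c2cn([C@@H]3C[C@H](C(=O)O)N(Cc4ccccc4)C3)nn2)cc1` gives < 10% in an assay on Sf9 cells for inhibition of histone deacetylase 11 (Homo sapiens), read by fluorescence, tested at 0.5 uM (on this read-out lower numbers stand for less inhibition and higher numbers for more inhibition at the one concentration tested (going by the name of the read-out)), which is a limit of the assay and not a number.
Compound 2 `O=C(NO)c1ccc(-c2cn([C@H]3C[C@@H](C(=O)O)N(Cc4ccccc4)C3)nn2)cc1` gives < 10% in this assay, which is also a limit and not a number.

Compound 1 and compound 2 are mirror images, and the step that the two limits leave unreadable from compound 1 to compound 2 cannot be read, since both values sit at the same limit of < 10% in this assay, at which 2 of the 2 values shown sit, and the pair differ only in configuration (the fact that compounds 1 and 2 differ only in the configuration as drawn). Compound 2 therefore stands at the limit of this assay, and nothing more precise is known about it.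

Compound 3 `O=C(NO)c1cccc(-c2cn([C@H]3C[C@@H](C(=O)O)N(Cc4ccccc4)C3)nn2)c1` keeps all atoms of compound 2 but joins them differently: 3-(hydroxycarbamoyl)phenyl in place of 4-(hydroxycarbamoyl)phenyl on an aromatic carbon. Among the measured compounds shown here, no measured step concerns a change of this kind; the one measured step is a mirror-image swap and is unreadable. For the measured compounds named here, the only guide is that both measured compounds stay at the limit, so compound 3 is expected to stay near it too, with the step from compound 2 estimated as a step that the limit leaves unreadable from compound 2 to compound 3. The estimate for compound 3 in this assay is 8%, in a range from 0% to 30%.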

Compound 3, a percentage reported as inhibition, at one concentration (the size of the read-out at that concentration, not a potency): 14%
The estimate for compound 3 lay 6 percentage points below the measured number, within the range that was stated.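

Moving the hydroxycarbamoyl group from 4-(hydroxycarbamoyl)phenyl to 3-(hydroxycarbamoyl)phenyl, on the same aromatic carbon of the shared core, gives the first reading in this assay that is a number and not a limit: compound 3 gives 14%. Among the compounds shown here, the change can therefore be read for the first time, as a number at least 4 percentage points higher from compound 2 to compound 3 (that floor lies within the scatter), and the two groups have the same heavy atoms and the same counts of donors and acceptors, so only the way they are joined differs. This gives a floor for the step and not its size, and the series as shown still rests mostly on limits: the limit of < 10% in this assay, at which 2 of the 3 values shown sit.

The compounds shown leave open whether the mirror image of compound 3 would give a similar reading, since the one mirror-image pair so far cannot be read. They also leave open whether an amine on the phenyl ring in place of the hydroxycarbamoyl group, or a longer chain between that ring and the hydroxycarbamoyl group, would give a step that clearly exceeds the scatter.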